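Compound 3: chloro in place of fluoro

The source may hold more compounds than are shown below. What is called first, only, known or untested is meant among the compounds shown, and "the series" means these compounds.

The compounds in this series share one core and differ in a single halogen. For the measured compounds named here, in an ADME assay on the whole organism (Rattus norvegicus, strain Sprague-Dawley) for metabolic stability, read by LC-MS, with a stated time of 48 h, at a dose of 10 mg/kg by the oral route (on this read-out higher numbers stand for a longer-lived compound and lower numbers for a shorter-lived compound), compound 1 `CC#CCn1c(N2CCC[C@@H](N)C2)cc(=O)n(Cc2ccc(Br)c(C(=O)OC)c2)c1=O` gives a half-life of 2.52 h, and compound 2 `CC#CCn1c(N2CCC[C@@H](N)C2)cc(=O)n(Cc2ccc(F)c(C(=O)OC)c2)c1=O` gives 6.29 h, the higher of the two numbers so far. Compound 3 `CC#CCn1c(N2CCC[C@@H](N)C2)cc(=O)n(Cc2ccc(Cl)c(C(=O)OC)c2)c1=O` has not yet been measured. It departs from compound 2 by chloro in place of fluoro on an aromatic carbon. Going by the values given here, one measured step bears on this change: fluoro in place of bromo at the same place gave a 2.5-fold higher number from compound 1 to compound 2 (0.40 log units; beyond the scatter), a modest step beyond the scatter. Among the compounds with values here, two compounds do not establish a trend, and no chloro compound has a measured number. The change to compound 3 moves away from fluoro, the opposite sense to that step, so a lower number in this assay is expected, most likely by less than the measured step and possibly within the scatter. The expected change is a 1.6-fold lower number from compound 2 to compound 3 (0.20 log units; within the scatter). For compound 3, the estimated half-life is 4 h, with an expected range of 2.2 h to 7.5 h.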

Compound 3, half-life: 2.43 h
Compound 3: the middle estimate sits 1.6-fold (0.22 log units) above what was measured; low and high end bracket the measured number.
By their numbers in this assay, from the lowest: compounds 3 and 1 (each within the scatter of the next); then compound 2.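

In this assay, chloro on this aromatic carbon, ortho to a methoxycarbonyl group, gives a 2.6-fold lower number from compound 2 to compound 3 (0.41 log units; beyond the scatter) in the half-life, a step much the same in size as the one between bromo and fluoro (a 2.5-fold higher number from compound 1 to compound 2 (0.40 log units; beyond the scatter)). Chloro and bromo are not separated at this position, with a 1.0-fold lower number from compound 1 to compound 3 (0.02 log units; within the scatter) as the step between them, so the three halogens fall into two sets: fluoro alone, and chloro with bromo, with compound 2 the only one of the three whose steps to both others are beyond the scatter. No measurement at hand accounts for this difference between fluoro and the other two halogens.

Going by these compounds, it remains open whether a hydrogen, a methyl or a nitrile on the same carbon would fall with fluoro, with chloro and bromo, or apart from both. On these data alone, it is also open whether the gap between fluoro and the other two halogens would persist if a carboxylic acid or a primary amide stood in place of the methoxycarbonyl group.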